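Replacing one thiazole end of a bivalent histamine guanidine

The source may hold more compounds than are shown below. What is called first, only, known or untested is meant among the compounds shown, and "the series" means these compounds.

Two dimeric acylguanidines were measured in an in vitro functional assay on Sf9 cells for agonist activity at histamine H2 receptor (Homo sapiens); a higher number here means that more compound is needed for the effect, a lower number that less compound is needed. Compound 1 `Cc1nc(N)sc1CCCN/C(N)=N/C(=O)CCCCC(=O)/N=C(\N)NCCCc1sc(N)nc1C` carries a shorter linker between its two acylguanidine units and gives 57.5 nM. Among the measured compounds shown here, compound 2 `Cc1nc(N)sc1CCCN/C(N)=N/C(=O)CCCCCCCCC(=O)/N=C(\N)NCCCc1sc(N)nc1C` carries the longer linker and gives 7.76 nM, the lowest of the two numbers; its only neighbour is compound 1, which lies higher by a margin beyond the usual scatter, so on these two numbers compound 2 needs less compound for the effect.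

Compound 3 `Cc1nc(N)sc1CCCN/C(N)=N/C(=O)CCCCCCCCC(=O)/N=C(\N)NCCCc1c[nH]cn1` has not yet been measured. It differs from compound 2 in one place: 1H-imidazol-4-yl in place of 2-amino-4-methyl-1,3-thiazol-5-yl on a saturated chain carbon, three bonds along the chain from an amine nitrogen. The other end of the molecule, the linker and both acylguanidine units are unchanged.

For the measured compounds named here, no measured pair in this set shows this change, so its size is not known from data. Only the two linker lengths have been compared. For compound 3 in this assay a modest rise is expected, about a 1.9-fold higher number from compound 2 to compound 3 (0.29 log units; within the scatter), with the result expected near 15 nM, plausibly between 5 nM and 50 nM.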

Compound 3, half-maximal effective concentration: 7.59 nM
Compound 3: the middle estimate sits 2.0-fold (0.30 log units) above what was measured; the range from low to high includes it.
By their numbers in this assay, from the lowest: compounds 3 and 2 (each within the scatter of the next); then compound 1.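

In this assay, among the compounds shown here, this is the first step read at this position, and the exchange comes to a 1.0-fold lower number from compound 2 to compound 3 (0.01 log units; within the scatter) with the longer linker in place. On this read-out, then, 1H-imidazol-4-yl and 2-amino-4-methyl-1,3-thiazol-5-yl cannot be told apart on this saturated chain carbon, even though the entering group has fewer heavy atoms and hydrogen-bond acceptors and the other end of the molecule stays as it was. Nothing measured here explains why the two groups give matching numbers.

For the compounds shown here, whether the same exchange holds with the shorter linker of compound 1 stays open, as the step has been read on only one chain length. Also open, going by these compounds, is what happens when the second 2-amino-4-methyl-1,3-thiazol-5-yl end carries 1H-imidazol-4-yl as well, or when either end on the propyl chain is replaced by a phenyl ring or a simple primary amine.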